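Furan to Thiophene on a Dihydropyrimidinone Core

This account rests on a few compounds, and the source may have more. Where it says the series, first, only, none or still open, it means among the compounds named here.

Two compounds sharing a six-membered non-aromatic ring with two nitrogens have been tested in an assay on membranes from CHO cells for displacement of a labelled ligand from adenosine receptor A1 (Homo sapiens), read by scintillation counting, with a stated time of 60 min, tested at 1 uM; a lower number here means less inhibition, a higher number more inhibition at the concentration tested (going by the name of the read-out). Compound 1 `COC(=O)C1=C(C)NC(=O)NC1c1cccs1` gives 6% in this assay. Compound 2 `CC1=C(c2ncc(C)o2)C(c2ccco2)NC(=O)N1` gives 27% in this assay, the higher of the two numbers, and the gap to compound 1 is beyond the usual scatter. Compound 3 `CC1=C(c2ncc(C)o2)C(c2cccs2)NC(=O)N1` has not yet been measured in this assay. It differs from compound 2 in one place: thiophen-2-yl in place of furan-2-yl on a saturated ring carbon. Among the measured compounds shown here, no measured pair shows what this exchange does on this core, so the expectation rests on the value of compound 2 alone. The step of a number 3 percentage points higher from compound 2 to compound 3 (within the scatter) is expected to be small, with no clear direction and probably within the scatter. Compound 3 is therefore estimated at 30% in this assay, with a plausible range from 12% to 50%.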

Compound 3, a percentage reported as inhibition, at one concentration (the size of the read-out at that concentration, not a potency): 21%
Estimate against measurement, compound 3: 9 percentage points above; the measured number falls inside the stated range.
By their numbers in this assay, from the lowest: compound 1; then compounds 3 and 2 (each within the scatter of the next).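

In this assay, thiophen-2-yl in place of furan-2-yl on the saturated ring carbon gives a number 6 percentage points lower from compound 2 to compound 3 (within the scatter), so this read-out does not separate the two rings at this position on the shared core. Among the compounds shown here, compound 3 also forms a pair with compound 1, and 5-methyl-1,3-oxazol-2-yl in place of methoxycarbonyl on a double-bonded ring carbon gives a number 15 percentage points higher from compound 1 to compound 3 (beyond the scatter), the first single-place change here to lie beyond the scatter. No measurement at hand accounts for either step.

The compounds shown leave open whether a phenyl or a cyclohexyl group at the saturated ring carbon would keep the read-out in the same range. They also leave open whether the exchange between the two rings would behave alike with methoxycarbonyl on the double-bonded ring carbon.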